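Notes on the amine swap from compound 2

A few compounds are considered here, and "the series" means these few. Any claim that something is new, unique, unknown or untested is made for them only; others in the source may bear on it.

Measured so far, in a physicochemical assay for solubility, measured as kinetic solubility; on this read-out higher numbers stand for higher solubility and lower numbers for lower solubility:
Compound 1, `O=C(Nc1cccc(F)c1)c1cc(C(F)(F)F)ccc1OCc1ccc(F)cc1`, gives < 1000 nM, a limit of the assay.
Compound 2, `CN1CCC(c2ccc(OCc3ccccc3)c(C(=O)Nc3ccnnc3)c2)CC1`, gives 71000 nM.
Compound 3, `N#Cc1cccc(NC(=O)c2cc(C(F)(F)F)ccc2OCc2ccc(F)cc2)c1`, gives < 1000 nM, a limit of the assay.

Among the measured compounds shown here, compound 2 holds the only number in this assay; the two other values are limits, as recorded in the limit of < 1000 nM in this assay, at which 2 of the 3 values shown sit. Compound 4, `CN1CC2(CCN(c3ccc(OCc4ccccc4)c(C(=O)Nc4ccnnc4)c3)CC2)C1`, differs from compound 2 at one place: a group of 10 heavy atoms (8 carbon, 2 nitrogen; one four-membered non-aromatic ring with 1 hetero atom, one six-membered non-aromatic ring with 1 hetero atom) in place of a group of 7 heavy atoms (6 carbon, 1 nitrogen; one six-membered non-aromatic ring with 1 hetero atom), on an aromatic carbon. For the measured compounds named here, the single measured step, a step that the two limits leave unreadable from compound 1 to compound 3, concerns compounds built on another core and has no readable size, so no measured step bears on the change from compound 2 to compound 4. With nothing to scale from, the expected step of a 1.1-fold higher number from compound 2 to compound 4 (0.02 log units; within the scatter) is set at none beyond the scatter. Compound 4 is therefore estimated at 75000 nM, with a range from 25000 nM to 220000 nM.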

Compound 4, solubility: 266000 nM
For compound 4 the middle estimate is 3.5-fold (0.55 log units) below the measured one; the whole stated range lies below it.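

In this assay, the aromatic carbon para to a benzyloxy group gives the first readable step, with the four-membered and six-membered ring group replacing 1-methylpiperidin-4-yl: a 3.7-fold higher number from compound 2 to compound 4 (0.57 log units; beyond the scatter). A change at this one place, with the shared core kept, thus moves the number beyond the scatter. No measurement shown gives a cause for this step.

From the compounds shown here alone, how a morpholine or a carboxylic acid at this position would read stays open. The step between compound 1 and compound 3 cannot be read, so the core of compound 1 offers no comparison.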